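Aryl Swap on the Hydrazide Nitrogen in Two Isomeric Sulfonamides

The source may hold more compounds than are shown below. What is called first, only, known or untested is meant among the compounds shown, and "the series" means these compounds.

Measured compounds in a functional assay on MDA-MB-231 cells (Homo sapiens) for antiproliferative activity, read by MTT assay, with a stated time of 24 h; a lower number here means a stronger inhibitor, a higher number a weaker inhibitor:
compound 1 `O=C(NNc1cccc(Cl)c1)c1ccc(NS(=O)(=O)c2cnc(O)nc2O)cc1`: 17400 nM
compound 2 `O=C(NNc1ccccc1F)c1ccc(NS(=O)(=O)c2cnc(O)nc2O)cc1`: > 20000 nM (a limit of the assay)
compound 3 `O=C(NNc1cccc(Cl)c1)c1cccc(NS(=O)(=O)c2cnc(O)nc2O)c1`: 7760 nM

Of the compounds shown here, three have been measured in this assay. Compound 1 gives 17400 nM. For compound 2 the assay reports only a limit, > 20000 nM. Compound 3 gives 7760 nM, the lowest of the two numbers; its nearest neighbour is compound 1, which sits a distance away that lies beyond the usual scatter. Compound 1 and compound 3 are built from the same atoms joined differently, and the difference between the two cores is not broken down here.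

The change from compound 1 to compound 2 is 2-fluorophenyl in place of 3-chlorophenyl on an amine nitrogen. It produced an at least 1.1-fold higher number from compound 1 to compound 2 (0.06 log units; that floor lies within the scatter), and since the value of compound 2 is the limit of > 20000 nM in this assay, at which 1 of the 3 values shown sits, the true size of that step is not known beyond its floor.

Compound 4 `O=C(NNc1ccccc1F)c1cccc(NS(=O)(=O)c2cnc(O)nc2O)c1` has not yet been measured. It stands to compound 3 as compound 2 stands to compound 1: the change is 2-fluorophenyl in place of 3-chlorophenyl on an amine nitrogen. Within the data shown here, because the only measured instance of this change gave an at least 1.1-fold higher number from compound 1 to compound 2 (0.06 log units; that floor lies within the scatter), a weakening of at least that floor, and possibly more, is expected from compound 3 to compound 4 as well, though from a stronger starting point. The step from compound 3 to compound 4 is estimated at a 1.7-fold higher number from compound 3 to compound 4 (0.22 log units; within the scatter). For compound 4 the expected value in this assay is 13000 nM, with a range from 6000 nM to 25000 nM.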

Compound 4, half-maximal inhibitory concentration: > 20000 nM
Compound 4 gave a limit, no number (the forecaster's own chance of this, stated with the estimate: 30%); middle value at least 1.5-fold (0.18 log units) away from the limit.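

In this assay, compound 4 returned only a limit of the assay, > 20000 nM, and not a number. Even so, placing 2-fluorophenyl where 3-chlorophenyl stood on the amine nitrogen gives an at least 2.5-fold higher number from compound 3 to compound 4 (0.41 log units; beyond the scatter), so on this core the change weakens the compound by more than the usual scatter, whereas the floor of the earlier step on the core of compound 1 does not establish that by itself. This shows that the change carries a clear loss on one core and is compatible with a loss on the other, but it does not show that the effect transfers with the same size, as the comparison of the two steps remains unresolved: the same change on two cores in this assay, an at least 1.1-fold higher number (0.06 log units; that floor lies within the scatter) from compound 1 to compound 2 and an at least 2.5-fold higher number (0.41 log units; beyond the scatter) from compound 3 to compound 4; the limit leaves it open whether they differ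

The compounds shown leave open how far compound 2 and compound 4 actually lie past the limit, and with it the true size of both steps: the limit of > 20000 nM in this assay, at which 2 of the 4 values shown sit. They also leave open how an unsubstituted phenyl or a methoxyphenyl on that amine nitrogen would behave on either core, and so whether the loss belongs to 2-fluorophenyl itself or whether 3-chlorophenyl is the unusual member of this small set.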